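The source may report more compounds than this note shows. Statements on the series, on what has been measured and on what is new or still open speak of the compounds shown alone.

In a functional assay on A549 cells (Homo sapiens) for inhibition, read by sulforhodamine B assay, with a stated time of 48 h (on this read-out lower numbers stand for stronger inhibition of growth and higher numbers for weaker inhibition of growth), three hydroxamic acids with the shared core have been measured. Compound 1 (`CCN(C(=O)c1cc(C(C)C)c(O)cc1O)c1ccc(NC(=O)CCCCCCC(=O)NO)cc1`) gives 5630 nM, compound 3 (`CCN(C(=O)c1cc(C(C)C)c(O)cc1O)c1cccc(NC(=O)CCCCCCC(=O)NO)c1`) gives 1590 nM, and compound 2 (`CC(C)c1cc(C(=O)N(C)c2ccc(NC(=O)CCCCCCCC(=O)NO)cc2)c(O)cc1O`) gives 440 nM. Compound 2 therefore has the lowest number of the three, clearly beyond the scatter from both of the others.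

Compound 4 (`CC(C)c1cc(C(=O)N(C)c2ccc(NC(=O)CCCCCC(=O)NO)cc2)c(O)cc1O`) has not yet been measured. It departs from compound 2 at one place, on a saturated chain carbon, five bonds along the chain from a carbonyl carbon, where hydroxycarbamoyl stands in place of 2-(hydroxycarbamoyl)ethyl: hydroxycarbamoyl in place of 2-(hydroxycarbamoyl)ethyl on a saturated chain carbon, five bonds along the chain from a carbonyl carbon.

Among the measured compounds shown here, no measured pair isolates this change. For the measured compounds named here, the only guide is indirect: compound 1 has a shorter chain than compound 2 but also differs elsewhere, and compound 1 gives 5630 nM. A weakening of growth inhibition beyond the scatter is therefore expected, with the estimated step being a 4.1-fold higher number from compound 2 to compound 4 (0.61 log units; beyond the scatter). For compound 4 the estimated value is 1800 nM, with an expected range of 550 nM to 6000 nM.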

Compound 4, concentration for 50% growth inhibition: 2830 nM
Compound 4: the middle estimate sits 1.6-fold (0.20 log units) below what was measured, and the stated range covers the measured number.
By their numbers in this assay, from the lowest: compound 2; then compounds 3, 4 and 1 (each within the scatter of the next, the first and the last beyond it).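

Among the compounds shown here, this is the first pair in which the chain alone changes: in this assay, putting hydroxycarbamoyl in place of 2-(hydroxycarbamoyl)ethyl on a saturated chain carbon, five bonds along the chain from a carbonyl carbon, gives a 6.4-fold higher number from compound 2 to compound 4 (0.81 log units; beyond the scatter) with nothing else altered. Shortening the chain at this position therefore weakens growth inhibition beyond the scatter on its own, a link that the earlier compounds, which differ in more than one place, could not establish. No measurement is available that explains the size of this step.

Going by these compounds, it remains open whether a longer chain than that of compound 2 would lower the number further or raise it again. Also open, on these data alone, is whether a carboxylic acid in place of the hydroxycarbamoyl end would retain any growth inhibition.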